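Adding a Hydroxyl to the Aryl Ring: What to Expect

A few compounds are considered here, and "the series" means these few. Any claim that something is new, unique, unknown or untested is made for them only; others in the source may bear on it.

Measured compounds:
compound 1 `COc1ccc(C2CC(Nc3nc4ccc(Cl)cc4s3)=NN2C(C)=O)cc1`: 97.3 umol/kg
compound 2 `CC(=O)N1N=C(Nc2nc3ccc(Cl)cc3s2)CC1c1ccccc1`: "not determined" (no result reported)
compound 3 `CC(=O)N1N=C(Nc2nc3ccccc3s2)CC1c1ccccc1`: "not determined" (no result reported)

All three share one core and were tested in a functional assay on the whole organism (strain albino) with Mus musculus as the target, with a stated time of 0.5 h; a higher number here means that more compound is needed for the effect, a lower number that less compound is needed. Compound 1 gives 97.3 umol/kg. Among the measured compounds shown here, compound 2 stands without a number in this assay, and compound 3 likewise has none, so compound 1 supplies the only measured value. Compound 4 `COc1ccc(C2CC(Nc3nc4ccc(Cl)cc4s3)=NN2C(C)=O)cc1O` differs from compound 2 in one place: 3-hydroxy-4-methoxyphenyl in place of phenyl on a saturated ring carbon. The change puts 3-hydroxy-4-methoxyphenyl in place of phenyl on a saturated ring carbon. For the measured compounds named here, no measured pair shows what such a change does, so no shift beyond the usual scatter of this assay is expected in either direction. Going by the values given here, the one number available is that of compound 1, 97.3 umol/kg. On that basis compound 4 is expected to give about 100 umol/kg, within a range from 30 umol/kg to 300 umol/kg.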

Compound 4, dose for half-maximal effect: 132 umol/kg
Compound 4: the middle estimate sits 1.3-fold (0.12 log units) below what was measured; measured number inside the range.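

Among the compounds shown here, this is the first measured pair at this position: in this assay, hydroxy in place of hydrogen on an aromatic carbon gives a 1.4-fold higher number from compound 1 to compound 4 (0.13 log units; within the scatter). The 3-hydroxy-4-methoxyphenyl group and the ring without the hydroxy therefore cannot be told apart in this test. No evidence available here bears on this result.

The step from phenyl to 3-hydroxy-4-methoxyphenyl cannot be read, as compound 2 has no number. Also open, going by these compounds, is what an amine or a carboxylic acid would do in place of the hydroxy.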